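A few compounds are considered here, and "the series" means these few. Any claim that something is new, unique, unknown or untested is made for them only; others in the source may bear on it.

Compound 1 `CC(C)CCn1ccc(-c2ccc(OCC3CC3)cc2)c(C#N)c1=O`: 290 nM
Compound 2 `CC(C)CCn1ccc(-c2ccc(OCC3CC3)c(Cl)c2)c(C#N)c1=O`: 110 nM
Compound 3 `CC(C)CCn1ccc(-c2ccc(Oc3cccnc3)cc2)c(C#N)c1=O`: 479 nM

In a functional assay on CHO cells for positive allosteric modulation of metabotropic glutamate receptor 2 (Homo sapiens), read by scintillation counting and GTPgammaS binding, with a stated time of 30 min (a lower number here means that less compound is needed, a higher number that more compound is needed for the effect), compound 2 holds the lowest number of the three measured compounds. The step of a 2.6-fold lower number from compound 1 to compound 2 (0.42 log units; beyond the scatter) sets it apart from compound 1, and compound 3 lies further away still, with the step of a 1.7-fold higher number from compound 1 to compound 3 (0.22 log units; within the scatter) falling inside the usual scatter.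

Compound 4 `CC(C)CCn1ccc(-c2ccc(NC3CCOCC3)c(Cl)c2)c(C#N)c1=O` differs from compound 2 in one place: (oxan-4-yl)amino in place of cyclopropylmethoxy on an aromatic carbon. The chloro group of compound 2 is kept. Going by the values given here, two measured steps bear on this change. The step of a 1.7-fold higher number from compound 1 to compound 3 (0.22 log units; within the scatter) also exchanged the cyclopropylmethoxy group for another group and produced only a small shift. The step of a 2.6-fold lower number from compound 1 to compound 2 (0.42 log units; beyond the scatter) concerns the chloro group, which is unchanged here, so it says nothing directly about the new group. The record therefore points to a modest change at most, with no clear direction; a slight rise in the number is taken as somewhat more likely than a fall, given that compound 3 sits above compound 1.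

Compound 4 is expected to give 180 nM, with a range from 50 nM to 650 nM. The expected step is a 1.6-fold higher number from compound 2 to compound 4 (0.21 log units; within the scatter).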

Compound 4, half-maximal effective concentration: 174 nM
Compound 4: the middle estimate sits 1.0-fold (0.01 log units) above what was measured, within the range that was stated.
By their numbers in this assay, from the lowest: compounds 2, 4, 1 and 3 (each within the scatter of the next, the first and the last beyond it).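

Until now, every change at this place had kept the oxygen on the aromatic carbon, whereas here the whole cyclopropylmethoxy group gives way to (oxan-4-yl)amino, ortho to the chloro group. Although the entering group carries a six-membered non-aromatic ring with 1 hetero atom and a hydrogen-bond donor that the leaving group lacks, the result is a 1.6-fold higher number from compound 2 to compound 4 (0.20 log units; within the scatter) and so shows that this larger, nitrogen-linked group can stand here without a change beyond the scatter. Nothing available accounts for this tolerance.

Going by these compounds, it remains open whether (oxan-4-yl)amino would give a similar step on the core of compound 1, without the chloro group. On these data alone, it is also open how a simple dimethylamino group or a carboxylic acid would fare at this place.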